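Acetyl for 2-(methoxycarbonyl)ethenyl on a shared core

A few compounds are considered here, and "the series" means these few. Any claim that something is new, unique, unknown or untested is made for them only; others in the source may bear on it.

Measured in a functional assay on A549 cells (Homo sapiens) for inhibition, read by MTT assay, with a stated time of 72 h (on this read-out lower numbers stand for stronger inhibition of growth and higher numbers for weaker inhibition of growth), so far:
Compound 1 (`COC(=O)/C=C/C1=CC[C@H]2C(C)(C)CCC[C@]2(C)[C@H]1C=O`) gives 21000 nM
Compound 2 (`CC1(C)CCC[C@]2(C)[C@@H](C=O)C(/C=C/C(=O)OCc3ccccc3)=CC[C@@H]12`) gives 28000 nM
Compound 3 (`COC(=O)/C=C/C=C/C1=CC[C@H]2C(C)(C)CCC[C@]2(C)[C@H]1C=O`) gives 29000 nM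

On these numbers, compound 3 lies within the scatter of both compound 1 and compound 2. Compound 4 (`CC(=O)/C=C/C1=CC[C@H]2C(C)(C)CCC[C@]2(C)[C@H]1C=O`) differs from compound 3 by acetyl in place of 2-(methoxycarbonyl)ethenyl on a double-bonded chain carbon bound to a double-bonded chain carbon. The measured step at this same place (a 1.4-fold higher number from compound 1 to compound 3 (0.14 log units; within the scatter)) and the step that adds phenyl (a 1.3-fold higher number from compound 1 to compound 2 (0.12 log units; within the scatter)) both stayed within the scatter, so no step beyond it is expected in this assay here. The expected step is small (a 1.2-fold lower number from compound 3 to compound 4 (0.06 log units; within the scatter)). Compound 4 is estimated at 25000 nM with an expected range from 12000 nM to 50000 nM in this read-out.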

Compound 4, concentration for 50% growth inhibition: 24000 nM
Compound 4: the middle estimate sits 1.0-fold (0.02 log units) above what was measured, within the range that was stated.
By their numbers in this assay, from the lowest: compounds 1, 4, 2 and 3 (each within the scatter of the next).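

In this assay, the carbonyl end of this chain tolerates a change from ester to acetyl: methyl in place of methoxy on a carbonyl carbon gives (a 1.1-fold higher number from compound 1 to compound 4 (0.06 log units; within the scatter)), and methyl in place of benzyloxy on a carbonyl carbon gives (a 1.2-fold lower number from compound 2 to compound 4 (0.07 log units; within the scatter)). Acetyl in place of 2-(methoxycarbonyl)ethenyl, with fewer heavy atoms, also stays within the scatter (a 1.2-fold lower number from compound 3 to compound 4 (0.08 log units; within the scatter)). No evidence is available on what lies behind these results. As far as these compounds go, whether an amine or a carboxylic acid at this place would give a step beyond the scatter remains open.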